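Trifluoromethyl Enters the Benzyl Arm of Compound 1

A few compounds are considered here, and "the series" means these few. Any claim that something is new, unique, unknown or untested is made for them only; others in the source may bear on it.

Measured so far:
compound 1, `COC(=O)C[C@H](NC(=O)OC(C)(C)C)C(=O)N(Cc1ccccc1)C1(C(=O)NCc2ccccc2)CCN(Cc2ccccc2)CC1`: > 100000 nM
compound 2, `COC(=O)C[C@H](NC(=O)OC(C)(C)C)C(=O)N(Cc1ccc(F)cc1)C1(C(=O)NCc2ccccc2)CCNCC1`: 100000 nM

In an ADME assay on MDCK cells (Canis lupus familiaris) for cytotoxicity, read by microscopy, with a stated time of 72 h (a lower number here means that less compound is tolerated, a higher number that more compound is tolerated), compound 1 gives > 100000 nM, which is a limit of the assay and not a number. Compound 1 therefore stands at the limit of > 100000 nM in this assay, at which 1 of the 2 values shown sits. For the measured compounds named here, compound 2, the only other measured compound, gives 100000 nM in this assay. Compound 3, `COC(=O)C[C@H](NC(=O)OC(C)(C)C)C(=O)N(Cc1ccc(C(F)(F)F)cc1)C1(C(=O)NCc2ccccc2)CCN(Cc2ccccc2)CC1`, is built from compound 1 by one change: trifluoromethyl in place of hydrogen on an aromatic carbon. Going by the values given here, no step between two measured compounds is available to guide the expectation. Among the compounds with values here, since compound 1 sits at a limit, the only step that could register in this assay is one toward less tolerated compound, and I expect such a step to be small, close to the scatter, as an at least 1.4-fold lower number from compound 1 to compound 3 (0.15 log units; that floor lies within the scatter). For compound 3 I estimate 70000 nM, with a range from 25000 nM to 100000 nM.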

Compound 3, minimum cytotoxic concentration: 84000 nM
For compound 3 the middle estimate is 1.2-fold (0.08 log units) below the measured one; the range from low to high includes it.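

In this assay compound 3, with its 4-(trifluoromethyl)benzyl group, gives a true number at this position, 84000 nM. Trifluoromethyl in place of hydrogen on this aromatic carbon reads as an at least 1.1-fold lower number from compound 1 to compound 3 (0.07 log units; that floor lies within the scatter), so the change shows no clear shift in how much compound the cells tolerate. The step can only be given as a floor because compound 1 stands at a limit of the assay and not at a number: the limit of > 100000 nM in this assay, at which 1 of the 3 values shown sits.

Going by these compounds, it remains open whether other groups at this place, such as a nitrile, a methoxy group or an amine, would move the number beyond the scatter. Also open, on these data alone, is how far the true value of compound 1 lies from its limit, which would set the real size of this step.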